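Aryl variation at the saturated ring carbon: compound 4

The source may hold more compounds than are shown below. What is called first, only, known or untested is meant among the compounds shown, and "the series" means these compounds.

Measured compounds, with their results in a functional assay on Ehrlich cells (Mus musculus) for antiproliferative activity, read by trypan blue exclusion, with a stated time of 2 h; a lower number here means a stronger inhibitor, a higher number a weaker inhibitor:
Compound 1 `Cc1ccc(C2C(C#N)=C(N)N(c3ccc(S(N)(=O)=O)cc3)C3=C2C(=O)CCC3)cc1` gives 50 ug/mL.
Compound 2 `COc1ccc(C2C(C#N)=C(N)N(c3ccc(S(N)(=O)=O)cc3)C3=C2C(=O)CCC3)cc1` gives 25 ug/mL.
Compound 3 `COc1cc(CC2C(C#N)=C(N)N(c3ccc(S(N)(=O)=O)cc3)C3=C2C(=O)CCC3)ccc1O` gives 25 ug/mL.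

Compound 3 stands level with compound 2, the two sharing the lowest number of the three; the step of no change at the digits printed from compound 2 to compound 3 (within the scatter), and against compound 1 the step of a 2.0-fold lower number from compound 1 to compound 3 (0.30 log units; within the scatter). All three numbers therefore sit within the scatter of one another, and no ordering among them can be claimed.

Compound 4 `COc1ccc(C2C(C#N)=C(N)N(c3ccc(S(N)(=O)=O)cc3)C3=C2C(=O)CCC3)c2ccccc12` is not yet measured. Its difference from compound 3 is 4-methoxynaphthalen-1-yl in place of 4-hydroxy-3-methoxybenzyl on a saturated ring carbon.

Within the data shown here, two measured steps touch the same saturated ring carbon: a 2.0-fold lower number from compound 1 to compound 3 (0.30 log units; within the scatter) and no change at the digits printed from compound 2 to compound 3 (within the scatter). Both remained within the scatter, so the groups tried so far at this carbon have not moved the number in this assay beyond what repeat measurements would show. The 4-methoxynaphthalen-1-yl group has not been measured anywhere in this set, and the numbers give no basis to expect a step beyond the scatter in either direction.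

Compound 4 is therefore expected to give about 25 ug/mL in this assay, within 12 ug/mL to 50 ug/mL; the step of no change at the digits printed from compound 3 to compound 4 (within the scatter) is estimated to stay within the scatter.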

Compound 4, half-maximal inhibitory concentration: 70 ug/mL
Compound 4: middle estimate off by 2.8-fold (0.45 log units), on the low side; measured number above the stated range.
By their numbers in this assay, from the lowest: compounds 2, 3, 1 and 4 (each within the scatter of the next, the first and the last beyond it).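

In this assay, among these compounds, the 4-methoxynaphthalen-1-yl group gives the first steps at this saturated ring carbon that pass the scatter, both modest and both toward a weaker inhibitor (a 2.8-fold higher number from compound 3 to compound 4 (0.45 log units; beyond the scatter) and a 2.8-fold higher number from compound 2 to compound 4 (0.45 log units; beyond the scatter)). The number at this carbon therefore does respond to the group it carries, although the step against the 4-methylphenyl group stays inside the scatter (a 1.4-fold higher number from compound 1 to compound 4 (0.15 log units; within the scatter)), leaving compound 4 apart from compound 2 and compound 3 but not from compound 1. Nothing measured bears on why the number rises with this group.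

Whether the second six-membered aromatic ring alone accounts for the step from the 4-methoxyphenyl group stays open, as the set holds neither an unsubstituted phenyl nor a naphthalen-1-yl without the methoxy group for comparison. Also open, from the compounds shown here alone, is how this carbon responds to groups unlike those tried so far, such as a 4-chlorophenyl, a 4-dimethylaminophenyl or a 4-carboxyphenyl, and whether a larger aromatic group than the naphthalene would extend the step.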